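This account rests on a few compounds, and the source may have more. Where it says the series, first, only, none or still open, it means among the compounds named here.

In a functional assay on DU-145 cells (Homo sapiens) for inhibition (a lower number here means a stronger inhibitor of growth, a higher number a weaker inhibitor of growth), compound 1 (`O=S(=O)(/C=C/c1ccc(Br)cc1)Cc1ccc(Nc2ncnc3ccccc23)cc1`) gives 55000 nM, compound 2 (`O=S(=O)(/C=C/c1ccc(Cl)c(Cl)c1)Cc1ccc(Nc2ncnc3ccc(Br)cc23)cc1`) gives 17000 nM, and compound 3 (`O=S(=O)(/C=C/c1ccc(Br)cc1)Cc1ccc(Nc2ncnc3ccc(Br)cc23)cc1`) gives 3000 nM. Compound 3 therefore has the lowest number of the three and is the strongest inhibitor of growth among them.

The next structure is compound 4 (`O=S(=O)(/C=C/c1ccc(O)cc1)Cc1ccc(Nc2ncnc3ccc(Br)cc23)cc1`). It differs from compound 3 by hydroxy in place of bromo on an aromatic carbon, para to a large group: hydroxy in place of bromo on an aromatic carbon. Going by the values given here, no measured step makes this exact exchange, so the evidence is indirect. The largest step, an 18-fold lower number from compound 1 to compound 3 (1.26 log units; beyond the scatter), also involves a bromo group, but that bromo lies elsewhere in the molecule and says little about this change. The closer guide is a 5.7-fold lower number from compound 2 to compound 3 (0.75 log units; beyond the scatter), a modest step with 4-bromophenyl in place of 3,4-dichlorophenyl. It shows that the number in this assay moves beyond the scatter when this aromatic group changes, although neither compound in that step carries a hydroxy group.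

With compound 3 already lowest of the series, a modest loss seems more likely than a further gain. The expected change is a 2.7-fold higher number from compound 3 to compound 4 (0.43 log units; beyond the scatter). Compound 4 is estimated at 8000 nM, with an expected range of 2000 nM to 35000 nM.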

Compound 4, concentration for 50% growth inhibition: 3000 nM
Beside the measured number, compound 4's estimate is 2.7-fold (0.43 log units) above it; the measured number falls inside the stated range.
By their numbers in this assay, from the lowest: compounds 3 and 4 (each within the scatter of the next); then compound 2; then compound 1.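

In this assay, hydroxy in place of bromo on an aromatic carbon, para to a large group, gives no change at the digits printed from compound 3 to compound 4 (within the scatter), so this position accepts either group with no difference that can be read, even though hydroxy brings a hydrogen-bond donor and acceptor that bromo lacks. Compound 4 also stands apart from the dichloro compound, with a 5.7-fold lower number from compound 2 to compound 4 (0.75 log units; beyond the scatter), a step of the same size as a 5.7-fold lower number from compound 2 to compound 3 (0.75 log units; beyond the scatter), so the 4-hydroxyphenyl and 4-bromophenyl compounds share the same margin over the 3,4-dichlorophenyl compound. Nothing measured on these compounds accounts for this tolerance or for that margin.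

As far as these compounds go, it remains open whether the same level holds for other groups at this place, such as an amine, a carboxylic acid or a longer chain such as propoxy. The step tied to the bromo on the shared core, an 18-fold lower number from compound 1 to compound 3 (1.26 log units; beyond the scatter), is shown only for the 4-bromophenyl series, so whether the 4-hydroxyphenyl series responds to that bromo in the same way also remains unknown.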